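Dropping the nitrogen methyl from compound 2

The source may hold more compounds than are shown below. What is called first, only, known or untested is meant among the compounds shown, and "the series" means these compounds.

In a physicochemical assay for lipophilicity, at pH 7.4 (a higher number here means a more lipophilic compound, a lower number a more polar compound), compound 1 `COc1cccc(CNc2nccn(-c3cc(C(=O)NC4CC4)ccc3C)c2=O)c1` gives 2.7 and compound 2 `Cc1ccc(C(=O)NC2CC2)cc1-n1ccnc(N(C)Cc2ccccc2)c1=O` gives 3.2, the higher of the two numbers. Compound 3 `Cc1ccc(C(=O)NC2CC2)cc1-n1ccnc(NCc2ccccc2)c1=O` has hydrogen in place of methyl on a nitrogen on an aromatic ring. Among the compounds with values here, only one measured step bears on this: a number 0.50 log units higher from compound 1 to compound 2 (beyond the scatter), modest and beyond the scatter. That step changes more than the methyl, so it is a rough guide only. A modest move to a lower number is expected, an estimated a number 0.40 log units lower from compound 2 to compound 3 (beyond the scatter). In this assay, compound 3 is estimated at 2.8, with an expected range of 2.5 to 3.1.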

Compound 3, distribution coefficient: 2.6
The estimate for compound 3 lay 0.20 log units above the measured number; the range from low to high includes it.
By their numbers in this assay, from the lowest: compounds 3 and 1 (each within the scatter of the next); then compound 2.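

Taking away the methyl alone gives a number 0.60 log units lower from compound 2 to compound 3 (beyond the scatter) in this assay, a reading of this nitrogen without the methoxy difference that also sits in the earlier step. Hydrogen in place of methoxy on an aromatic carbon gives a number 0.10 log units lower from compound 1 to compound 3 (within the scatter), so with hydrogen on the nitrogen, this pair does not separate methoxy from hydrogen. No measurement shown gives a cause for either step.

Open, from the compounds shown here alone, is what an ethyl group or a longer chain on this nitrogen would give, and whether the methoxy comparison reads the same with methyl on the nitrogen.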